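This account rests on a few compounds, and the source may have more. Where it says the series, first, only, none or still open, it means among the compounds named here.

In a functional assay on MCF7 cells (Homo sapiens) for cytotoxicity, read by MTT assay, with a stated time of 72 h (a higher number here means a weaker inhibitor, a lower number a stronger inhibitor), compound 2 `CNC(=O)c1cc(Oc2ccc(NC(=O)c3nn(-c4cccc(F)c4)c(=O)cc3C)cc2F)ccn1` gives 6410 nM, compound 1 `CNC(=O)c1cc(Oc2ccc(NC(=O)c3nn(-c4ccc(Br)cc4F)c(=O)cc3C)cc2F)ccn1` gives 9360 nM and compound 3 `CNC(=O)c1cc(Oc2ccc(NC(=O)c3nn(-c4ccc(C)cc4)c(=O)cc3C)cc2F)ccn1` gives 8380 nM. All three lie within the scatter of one another, so no order can be drawn among them, and compound 2 is simply the closest structural reference for the next analogue.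

Compound 4 `Cc1cc(=O)n(-c2cccc(F)c2)nc1C(=O)Nc1ccc(Oc2ncnc3sccc23)c(F)c1` differs from compound 2 by a group of 9 heavy atoms (6 carbon, 2 nitrogen, 1 sulfur; one five-membered aromatic ring with 1 hetero atom, one six-membered aromatic ring with 2 hetero atoms) in place of a group of 10 heavy atoms (7 carbon, 2 nitrogen, 1 oxygen; one six-membered aromatic ring with 1 hetero atom), on an oxygen on an aromatic ring. Three measured steps are available: a 1.5-fold lower number from compound 1 to compound 2 (0.16 log units; within the scatter), a 1.1-fold lower number from compound 1 to compound 3 (0.05 log units; within the scatter) and a 1.3-fold higher number from compound 2 to compound 3 (0.12 log units; within the scatter). Each lies within the scatter, but each changes the aryl group on an aromatic nitrogen. None touches the group on the oxygen, so the series offers no direct measure of this replacement.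

With only compound 2 at 6410 nM as an anchor, no step beyond the scatter is the central expectation, with no firm direction and a wide margin on both sides. For compound 4 the expected step is a 1.4-fold lower number from compound 2 to compound 4 (0.15 log units; within the scatter). The estimated value for compound 4 is 4500 nM, with an expected range of 900 nM to 15000 nM.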

Compound 4, half-maximal inhibitory concentration: 17300 nM
For compound 4 the middle estimate is 3.8-fold (0.58 log units) below the measured one; measured number above the stated range.
By their numbers in this assay, from the lowest: compounds 2, 3, 1 and 4 (each within the scatter of the next, the first and the last beyond it).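

Replacing the 2-(methylcarbamoyl)pyridin-4-yl group on the oxygen gives, in this assay, a 2.7-fold higher number from compound 2 to compound 4 (0.43 log units; beyond the scatter). For the compounds shown here, the changes of aryl group on the aromatic nitrogen all stayed within the scatter, so this is the first single change to move the number beyond it, and the direction is towards weaker inhibition. Nothing available accounts for this step.

The replacement alters the ring system and removes the methylcarbamoyl group in one move, so the contribution of each remains unresolved; a plain pyridin-4-yl group, or a pyridin-4-yl group carrying a carboxylic acid in place of the methylcarbamoyl, would bear on that question. Also open, on these data alone, is whether the step holds with the 4-methylphenyl or 4-bromo-2-fluorophenyl group on the aromatic nitrogen.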